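Acyl Variation at the Ring Nitrogen of the Shared Core

The compounds below may be only part of what the source reports. "The series", "measured", "known", "first", "only" and "open" are said of these compounds alone.

Measured so far in a functional assay on MDA-MB-231 cells (Homo sapiens) for cytotoxicity, read by sulforhodamine B assay, with a stated time of 72 h; on this read-out higher numbers stand for weaker inhibition of growth and lower numbers for stronger inhibition of growth:
- compound 1 `O=C(Nc1cc(C(F)(F)F)cc(C(F)(F)F)c1)C1CCc2ccccc2N1C(=O)c1ccccc1Cl`: 5250 nM
- compound 2 `CC(=O)N1c2ccccc2CCC1C(=O)Nc1cc(C(F)(F)F)cc(C(F)(F)F)c1`: > 70000 nM, which is a limit of the assay and not a number
- compound 3 `CCC(=O)N1c2ccccc2CCC1C(=O)Nc1cc(C(F)(F)F)cc(C(F)(F)F)c1`: 7280 nM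

Among the two numbers, compound 3 carries the higher one; its nearest neighbour is compound 1, with the step of a 1.4-fold higher number from compound 1 to compound 3 (0.14 log units; within the scatter), so the two cannot be told apart. Compound 2 sits at the assay limit (the limit of > 70000 nM in this assay, at which 1 of the 3 values shown sits). The two steps away from compound 2 are both large: an at least 13-fold higher number from compound 1 to compound 2 (1.12 log units; beyond the scatter) and an at least 9.6-fold lower number from compound 2 to compound 3 (0.98 log units; beyond the scatter). Within these three, the chain on the carbonyl carbon at the ring nitrogen thus matters, whereas the change from ethyl to 2-chlorophenyl does not.

Compound 4 `O=C(Nc1cc(C(F)(F)F)cc(C(F)(F)F)c1)C1CCc2ccccc2N1` carries no acyl group at all: hydrogen in place of propanoyl on a nitrogen on an aromatic ring in a ring. The measured step that bears most directly on this is an at least 9.6-fold lower number from compound 2 to compound 3 (0.98 log units; beyond the scatter), since shortening the chain by one carbon already pushed the number to the limit; the step from compound 1 to compound 3 adds nothing here. Removing the carbonyl chain entirely is therefore expected to raise the number, with a 6.9-fold higher number from compound 3 to compound 4 (0.84 log units; beyond the scatter) as the estimated step. For compound 4 in this assay the expected value is 50000 nM, within a range from 15000 nM to 150000 nM, with a real chance that only a limit is returned.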

Compound 4, concentration for 50% growth inhibition: 8270 nM
The estimate for compound 4 lay 6.0-fold (0.78 log units) above the measured number, outside the stated range (below it).
By their numbers in this assay, from the lowest: compounds 1, 3 and 4 (each within the scatter of the next). At a limit, above all of these: compound 2.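

Taking the acyl group off the ring nitrogen altogether leaves the read-out in this assay unresolved from that of the acylated compounds, both for propanoyl, with a 1.1-fold higher number from compound 3 to compound 4 (0.06 log units; within the scatter), and for (2-chlorophenyl)carbonyl, with a 1.6-fold higher number from compound 1 to compound 4 (0.20 log units; within the scatter). An acyl group at this nitrogen is therefore not required for a number in this range, and the earlier picture of the chain on the carbonyl carbon governing the result no longer holds as a general reading: acetyl is the only one of the four substituents set apart, with an at least 8.4-fold lower number from compound 2 to compound 4 (0.92 log units; beyond the scatter), and it goes against any trend with the size of the group. Compound 2 stands at a limit of the assay and has no number: the limit of > 70000 nM in this assay, at which 1 of the 4 values shown sits.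

Why acetyl alone parts from hydrogen, propanoyl and (2-chlorophenyl)carbonyl cannot be told from these four compounds. As far as these compounds go, it also remains open whether a longer chain such as butanoyl, an unsubstituted benzoyl or a plain methyl on this nitrogen would group with compound 1, compound 3 and compound 4 or with compound 2.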